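Cytotoxicity of triazole-bearing quinolines on pancreatic cancer cells

This account rests on a few compounds, and the source may have more. Where it says the series, first, only, none or still open, it means among the compounds named here.

Three compounds have been measured:
compound 1, `COc1nc2ccc(Br)cc2cc1C(c1ccccc1)n1cc(-c2ccccc2F)nn1`, giving 14.7%;
compound 2, `COc1nc2ccc(Br)cc2cc1C(c1ccccc1)n1cc(CCCO)nn1`, giving 25.5%;
compound 3, `COc1nc2ccc(Br)cc2cc1C(c1ccccc1)n1cc(CO)nn1`, giving 15%.

All three were tested in an ADME assay on PANC-1 cells (Homo sapiens) for cytotoxicity, read by sulforhodamine B assay, with a stated time of 48 h, tested at 10 uM; a lower number here means less inhibition, a higher number more inhibition at the concentration tested (going by the name of the read-out). Compound 3 stands second highest of the three numbers; its nearest neighbour is compound 1, and the step of a number 0.3 percentage points higher from compound 1 to compound 3 (within the scatter) lies within the scatter. Compound 2 is the furthest away, with a number 10.5 percentage points lower from compound 2 to compound 3 (beyond the scatter), which is beyond the scatter.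

Compound 4, `COc1nc2ccc(Br)cc2cc1C(c1ccccc1)n1cc(-c2ccc(F)cc2)nn1`, has not yet been measured. It differs from compound 3 in one place: 4-fluorophenyl in place of hydroxymethyl on an aromatic carbon. Among the compounds with values here, the step that bears on this change is the one between compound 1 and compound 3, in which an aryl group on the same ring carbon was exchanged for hydroxymethyl with no change beyond the scatter, a number 0.3 percentage points higher from compound 1 to compound 3 (within the scatter). Compound 4 carries an aryl group with the same fluorine count as compound 1, so the reverse of that step is the closest guide, and no step beyond the scatter is expected for no change at the digits printed from compound 3 to compound 4 (within the scatter). Compound 4 is therefore estimated at 15%, with a range of 5% to 27%.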

Compound 4, a percentage reported as inhibition, at one concentration (the size of the read-out at that concentration, not a potency): 14.9%
For compound 4 the middle estimate is 0.1 percentage points above the measured one, within the range that was stated.
By their numbers in this assay, from the lowest: compounds 1, 4 and 3 (each within the scatter of the next); then compound 2.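

Swapping 2-fluorophenyl for 4-fluorophenyl on this aromatic carbon gives a number 0.2 percentage points higher from compound 1 to compound 4 (within the scatter) in this assay, so moving the fluorine around the aryl ring leaves no mark that can be read here. The 4-fluorophenyl group, with its ring and no hydrogen-bond donor, also cannot be told apart from hydroxymethyl, with a number 0.1 percentage points lower from compound 3 to compound 4 (within the scatter). Only 3-hydroxypropyl stands apart, now against a second aryl group too, with a number 10.6 percentage points lower from compound 2 to compound 4 (beyond the scatter), while the hydroxy group of compound 3 brings no such separation.

Nothing shown here explains why the longer hydroxy chain alone stands apart. Going by these compounds, it remains open whether a butyl chain ending in hydroxy, or a propyl chain ending in an amine or a carboxylic acid, would take the number further from the group of three.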